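A few compounds are considered here, and "the series" means these few. Any claim that something is new, unique, unknown or untested is made for them only; others in the source may bear on it.

Measured compounds in a functional assay on DU-145 cells (Homo sapiens) for cytotoxicity, read by trypan blue exclusion, with a stated time of 96 h; on this read-out higher numbers stand for weaker inhibition and lower numbers for stronger inhibition:
- compound 1 `COC(=O)CCNc1cc(CS(=O)(=O)/C=C/c2c(OC)cc(OC)cc2OC)ccc1OC`: 1500 nM
- compound 2 `COC(=O)C(Nc1cc(CS(=O)(=O)/C=C/c2c(OC)cc(OC)cc2OC)ccc1OC)c1ccc(Br)cc1`: 300 nM

Compound 2 gives the lower of the two numbers, and its gap to compound 1 is beyond the scatter. Among the measured compounds shown here, the single measured step, a 5.0-fold lower number from compound 1 to compound 2 (0.70 log units; beyond the scatter), puts an aryl-bearing group on the nitrogen and is the only comparison bearing on the next change.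

Compound 3 `COc1cc(OC)c(/C=C/S(=O)(=O)Cc2ccc(OC)c(NC(C(=O)O)c3ccccc3)c2)c(OC)c1` differs from compound 2 thus: carboxy(phenyl)methyl in place of (4-bromophenyl)(methoxycarbonyl)methyl on a nitrogen on an aromatic ring. For the measured compounds named here, the aryl group stays, but no measured pair shows the effect of the acid in place of the ester or of losing the bromine, so a modest rise is expected rather than none, with wide uncertainty. For compound 3 the expected step is a 2.3-fold higher number from compound 2 to compound 3 (0.37 log units; beyond the scatter), giving an estimate of 700 nM with range 250 nM to 2500 nM.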

Compound 3, half-maximal inhibitory concentration: 20 nM
For compound 3 the middle estimate is 35-fold (1.54 log units) above the measured one; the whole stated range lies above it.
By their numbers in this assay, from the lowest: compound 3; then compound 2; then compound 1.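

Among the compounds shown here, on a nitrogen on an aromatic ring, carboxy(phenyl)methyl gives the lowest number so far in this assay, with a 15-fold lower number from compound 2 to compound 3 (1.18 log units; beyond the scatter) and a 75-fold lower number from compound 1 to compound 3 (1.88 log units; beyond the scatter). A free carboxylic acid on this position is therefore compatible with stronger inhibition, and the bromine is not needed for it. No available evidence accounts for the gain.

The acid and the loss of bromine change together, so their separate contributions remain unresolved. Also open, going by these compounds, is whether a primary amide or a tetrazole could replace the carboxylic acid.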